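A few compounds are considered here, and "the series" means these few. Any claim that something is new, unique, unknown or untested is made for them only; others in the source may bear on it.

Compound 1 `CC1=CC[C@H](C(C)(C)NC(=S)N/N=C/c2ccccc2O)CC1` gives 3100 nM in an ADME assay on Vero cells (Chlorocebus sabaeus) for inhibition, read by sulforhodamine B assay, with a stated time of 48 h; on this read-out lower numbers stand for stronger inhibition of growth and higher numbers for weaker inhibition of growth. Compound 2 `CC1=CC[C@H](C(C)(C)NC(=S)N/N=C/c2ccc(N(C)C)cc2)CC1` gives 75600 nM in this assay. Compound 3 `CC1=CC[C@H](C(C)(C)NC(=S)N/N=C/c2ccc(F)cc2)CC1` gives only the assay limit > 100000 nM in this assay.

Compound 3 thus stands at the limit of > 100000 nM in this assay, at which 1 of the 3 values shown sits, with no number of its own. Compound 4 `CC1=CC[C@H](C(C)(C)NC(=S)N/N=C/c2ccc[nH]2)CC1` differs from it by 1H-pyrrol-2-yl in place of 4-fluorophenyl on a carbon with a double bond to nitrogen. Within the data shown here, two measured steps bear on this change: an at least 32-fold higher number from compound 1 to compound 3 (1.50 log units; beyond the scatter) lies beyond the scatter, whereas an at least 1.3-fold higher number from compound 2 to compound 3 (0.12 log units; that floor lies within the scatter) does not. Among the measured compounds shown here, only the first shows that a change of this ring can move the number strongly. A modest step downward from the limit is expected, an at least 1.6-fold lower number from compound 3 to compound 4 (0.22 log units; that floor lies within the scatter), with a fair chance that only a limit is reported again. For compound 4 the estimate in this assay is 60000 nM, within 15000 nM to 200000 nM.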

Compound 4, concentration for 50% growth inhibition: 20500 nM
The estimate for compound 4 lay 2.9-fold (0.47 log units) above the measured number; the measured number falls inside the stated range.
By their numbers in this assay, from the lowest: compound 1; then compound 4; then compound 2. At a limit, above all of these: compound 3.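

On a carbon with a double bond to nitrogen, 1H-pyrrol-2-yl in place of 4-fluorophenyl gives a clear fall in the number in this assay, with an at least 4.8-fold lower number from compound 3 to compound 4 (0.68 log units; beyond the scatter), so a five-membered ring here can lift a compound off the limit. Compound 3 stays a limit, so this step is only a floor: the limit of > 100000 nM in this assay, at which 1 of the 4 values shown sits. The pyrrole does not match 2-hydroxyphenyl, with a 6.6-fold higher number from compound 1 to compound 4 (0.82 log units; beyond the scatter). Open, going by these compounds, is how a furan ring or a thiophene ring in this place would read in this assay.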